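One Amine Swap, Two Cores, One Open Question

This account rests on a few compounds, and the source may have more. Where it says the series, first, only, none or still open, it means among the compounds named here.

Compound 1 `COc1cc2ncnc(N3CCc4ccccc43)c2cc1NC(=O)/C=C/CN1CCCCC1` is the reference point. In a functional assay on MCF7 cells (Homo sapiens) for antiproliferative activity, read by MTT assay, with a stated time of 72 h (on this read-out lower numbers stand for stronger inhibition and higher numbers for weaker inhibition), compound 1 gives 1680 nM. Compound 2 `COc1cc2ncnc(N3CCc4ccccc43)c2cc1NC(=O)/C=C/CN1CCN(C)CC1` differs from it in one place: 4-methylpiperazin-1-yl in place of piperidin-1-yl on a saturated chain carbon bound to a double-bonded chain carbon. In this assay compound 2 gives 6430 nM. This change a 3.8-fold higher number from compound 1 to compound 2 (0.58 log units; beyond the scatter). Compound 3 `O=C(/C=C/CN1CCCCC1)Nc1cc2c(N3CCCc4ccccc43)ncnc2cc1O[C@@H]1CCOC1` carries a different core; the difference between the two cores is not broken down here. In this assay compound 3 gives 4450 nM, a figure that sits beside that of compound 2 within the usual scatter and stands apart from that of compound 1.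

Compound 4 `CN1CCN(C/C=C/C(=O)Nc2cc3c(N4CCCc5ccccc54)ncnc3cc2O[C@@H]2CCOC2)CC1` has not yet been measured. It stands to compound 3 exactly as compound 2 stands to compound 1: 4-methylpiperazin-1-yl in place of piperidin-1-yl on a saturated chain carbon bound to a double-bonded chain carbon. Since the place of the change is the same in both pairs, the same change is being made on a second core.

Because the same change a 3.8-fold higher number from compound 1 to compound 2 (0.58 log units; beyond the scatter), a weakening of similar size is expected when it is made on the core of compound 3, though a single earlier example gives only a rough guide, so the expected step from compound 3 to compound 4 is a 2.5-fold higher number from compound 3 to compound 4 (0.39 log units; beyond the scatter). For compound 4 in this assay the estimated value is 11000 nM, expected to fall between 5500 nM and 25000 nM.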

Compound 4, half-maximal inhibitory concentration: 7180 nM
Estimate against measurement, compound 4: 1.5-fold (0.19 log units) above; the range from low to high includes it.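

Putting 4-methylpiperazin-1-yl in place of piperidin-1-yl on the core of compound 3 gives, in this assay, a 1.6-fold higher number from compound 3 to compound 4 (0.21 log units; within the scatter), so on this core the step taken alone cannot be told apart from the ordinary spread of repeated measurements. Set beside the step on the core of compound 1, it gives no firm sign that the core alters what this change does: the same change on two cores in this assay, a 3.8-fold higher number (0.58 log units; beyond the scatter) from compound 1 to compound 2 and a 1.6-fold higher number (0.21 log units; within the scatter) from compound 3 to compound 4, 2.4-fold (0.38 log units) apart, within the scatter of two such steps. Going by these compounds alone, with only two pairs, however, this does not prove that the change acts alike on both cores, and it does not establish on the core of compound 3 the loss of activity that is clear on the core of compound 1.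

The compounds shown leave open whether other amines, such as morpholin-4-yl or dimethylamino, would behave alike on a saturated chain carbon bound to a double-bonded chain carbon. They also leave open whether the same pattern would hold on a third core.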